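The source may report more compounds than this note shows. Statements on the series, on what has been measured and on what is new or still open speak of the compounds shown alone.

Compound 1 `COc1cc(-n2ncnc2-c2cccc([N+](=O)[O-])c2)cc(OC)c1OC` in a functional assay on MCF7 cells (Homo sapiens) for antiproliferative activity, read by MTT assay, with a stated time of 72 h (a lower number here means a stronger inhibitor, a higher number a weaker inhibitor), gives > 10000 nM, which is a limit of the assay rather than a number.
Compound 2 `COc1cc(-c2ncnn2-c2cccc(N)c2)cc(OC)c1OC` in this assay gives > 10000 nM, also a limit.
Compound 3 `COc1cc(-c2ncnn2-c2ccc(Cl)c(Cl)c2)cc(OC)c1OC` in this assay gives > 10000 nM, again a limit.

Compound 1 therefore stands at the limit, as do the two other values; all of them sit at the limit of > 10000 nM in this assay, at which 3 of the 3 values shown sit. Compound 4 `COc1cc(-n2ncnc2-c2cccc(F)c2)cc(OC)c1OC` differs from compound 1 by fluoro in place of nitro on an aromatic carbon. Within the data shown here, the only measured step, a step that the two limits leave unreadable from compound 2 to compound 3, runs between two limits, so its size cannot be read. No measured step bears on a change of fluoro in place of nitro, and no shown step points toward a stronger inhibitor. Compound 4 is expected to remain at the limit, with an estimated 20000 nM and a range from 5000 nM to 100000 nM. The expected step is a step that the limit leaves unreadable from compound 1 to compound 4, estimated as no change beyond the scatter.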

Compound 4, half-maximal inhibitory concentration: > 10000 nM
Compound 4: no number, only a limit (the forecaster's own chance of this, stated with the estimate: 80%); the middle value does not contradict the limit.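

Compound 1 and compound 4 both give a limit rather than a number, and the size of the step from nitro to fluoro cannot be read. The compounds shown leave open which change, if any, would give a readable value in this assay.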